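Swapping the sulfur-linked ring for a quinolinyl ether

This account rests on a few compounds, and the source may have more. Where it says the series, first, only, none or still open, it means among the compounds named here.

Compound 1 `CC(C)[C@H](NC(=O)COc1cccc2ccccc12)C(=O)N[C@@H](CC(=O)O)C(=O)CSc1nc2ccccc2s1`: > 200000 nM
Compound 2 `CC(C)[C@H](NC(=O)COc1cccc2ccccc12)C(=O)N[C@@H](CC(=O)O)C(=O)CSc1nccc(C(F)(F)F)n1`: > 200000 nM

In a functional assay on Jurkat cells (Homo sapiens) for inhibition (on this read-out lower numbers stand for stronger inhibition and higher numbers for weaker inhibition), compound 1 gives > 200000 nM, which is a limit of the assay and not a number. In this assay compound 2 likewise gives > 200000 nM, again a limit. Compound 2 therefore stands at the limit of > 200000 nM in this assay, at which 2 of the 2 values shown sit, and the step that the two limits leave unreadable from compound 1 to compound 2 cannot be read. Compound 3 `CC(C)[C@H](NC(=O)COc1cccc2ccccc12)C(=O)N[C@@H](CC(=O)O)C(=O)COc1ccc2ccccc2n1` differs from compound 2 by (quinolin-2-yl)oxy in place of (4-(trifluoromethyl)pyrimidin-2-yl)sulfanyl on a saturated chain carbon bound to a carbonyl carbon. Within the data shown here, the only measured step touches the same place but carries no readable size, so the data give no direction for this change. A step of an at least 1.3-fold lower number from compound 2 to compound 3 (0.12 log units; that floor lies within the scatter) in this assay is therefore expected to be small or unreadable, with compound 3 most likely sitting near the same limit. Compound 3 is estimated at 150000 nM in this assay, within a range from 20000 nM to 300000 nM.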

Compound 3, half-maximal inhibitory concentration: > 200000 nM
Compound 3: only a limit was reported; the forecaster's own chance of this, stated with the estimate: 55%; middle value at least 1.3-fold (0.12 log units) away from the limit.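

In this assay compound 3 gives > 200000 nM as a limit and not a number. The steps among compound 1, compound 2 and compound 3 therefore cannot be read: the limit of > 200000 nM in this assay, at which 3 of the 3 values shown sit. Which of these three ring groups, if any, gives stronger inhibition in this assay stays open.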